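Cyclopentyloxy in place of tert-butyl on a carbonyl carbon

The source may report more compounds than this note shows. Statements on the series, on what has been measured and on what is new or still open speak of the compounds shown alone.

Going by the values given here, in a functional assay on HepG2 cells (Homo sapiens) for inhibition, read by scintillation counting, with a stated time of 2 h (a lower number here means a stronger inhibitor, a higher number a weaker inhibitor), compound 1 (`CCNC(=O)Nc1sc2ccccc2c1C(=O)N1CCN(C2CCN(C(=O)C3CCCC3)CC2)CC1`) gives 309 nM and compound 2 (`CCNC(=O)Nc1sc2ccccc2c1C(=O)N1CCN(C2CCN(C(=O)C(C)(C)C)CC2)CC1`) gives 450 nM, so compound 2 stands within the scatter of the only other measured compound. Compound 3 (`CCNC(=O)Nc1sc2ccccc2c1C(=O)N1CCN(C2CCN(C(=O)OC3CCCC3)CC2)CC1`) carries cyclopentyloxy in place of tert-butyl on a carbonyl carbon. Among the compounds with values here, the one measured step bearing on this change, tert-butyl in place of cyclopentyl on a carbonyl carbon, was a 1.5-fold higher number from compound 1 to compound 2 (0.16 log units; within the scatter). Within the data shown here, no measured pair yet shows what cyclopentyloxy does, so no step beyond the scatter is expected in this assay. The estimated change is a 1.3-fold lower number from compound 2 to compound 3 (0.11 log units; within the scatter). For compound 3 the expected value is 350 nM, with a range from 130 nM to 950 nM.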

Compound 3, half-maximal inhibitory concentration: 512 nM
The estimate for compound 3 lay 1.5-fold (0.17 log units) below the measured number; the range from low to high includes it.
By their numbers in this assay, from the lowest: compounds 1, 2 and 3 (each within the scatter of the next).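

In this assay the swap to cyclopentyloxy on this carbonyl carbon gives a 1.1-fold higher number from compound 2 to compound 3 (0.06 log units; within the scatter) when tert-butyl leaves and a 1.7-fold higher number from compound 1 to compound 3 (0.22 log units; within the scatter) when cyclopentyl leaves, so neither swap falls beyond the scatter. Among these three compounds, then, a ring joined through an oxygen cannot be told apart from a ring or a tert-butyl joined directly. No supporting evidence explains this result. Still open, going by these compounds, is whether an amine, a carboxylic acid or a longer chain at this carbonyl carbon would give a step beyond the scatter.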